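Sulfoxide to sulfamoyl on the benzylamide series

The source may hold more compounds than are shown below. What is called first, only, known or untested is meant among the compounds shown, and "the series" means these compounds.

Measured so far in an assay on HeLa cells with Bile acid receptor (Homo sapiens) as the target, read by a luciferase reporter, with a stated time of 24 h; a lower number here means that less compound is needed, a higher number that more compound is needed for the effect:
Compound 1, `CC(C)(C)c1ccc(C(=O)NCc2ccc(NC(=O)C(F)(F)F)cc2Cl)cc1`: 14 nM
Compound 2, `C[S+]([O-])c1ccc(CNC(=O)c2ccc(C(C)(C)C)cc2)cc1`: 1300 nM
Compound 3, `CC(NC(=O)c1ccc(C(C)(C)C)cc1)c1ccc(C(=O)O)cc1`: 76 nM

Compound 2 stands highest of the three numbers in this assay; compound 3 lies nearer to it and compound 1 furthest, both beyond the scatter. Compound 4, `CC(C)(C)c1ccc(C(=O)NCc2ccc(S(N)(=O)=O)cc2)cc1`, is not yet measured. It differs from compound 2 by a group of 4 heavy atoms (1 nitrogen, 2 oxygen, 1 sulfur; no ring) in place of a group of 3 heavy atoms (1 carbon, 1 oxygen, 1 sulfur; no ring), on an aromatic carbon. For the measured compounds named here, no step between two measured compounds matches this change, so the expectation rests on the values shown, with compound 3 at 76 nM and compound 1 at 14 nM both well under compound 2. A step to a lower number, beyond the scatter, is expected, as a 4.3-fold lower number from compound 2 to compound 4 (0.64 log units; beyond the scatter). Compound 4 is estimated at 300 nM, in the range 80 nM to 1200 nM.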

Compound 4, half-maximal effective concentration: 1400 nM
Estimate against measurement, compound 4: 4.7-fold (0.67 log units) below; the whole stated range lies below it.
By their numbers in this assay, from the lowest: compound 1; then compound 3; then compounds 2 and 4 (each within the scatter of the next).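

In this assay, for the compounds shown here, sulfamoyl in place of the sulfoxide, on an aromatic carbon para to a large group, gives a 1.1-fold higher number from compound 2 to compound 4 (0.03 log units; within the scatter), the first comparison that differs in one place. At this position, then, the exchange does not separate the two compounds, even though sulfamoyl carries a hydrogen-bond donor and the group it replaces carries none. No measured data bear on why the two compounds read alike. Open, going by these compounds, is whether a primary amine or a methylsulfonyl group at this position would shift the number beyond the scatter.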